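Trading methoxy for trifluoromethyl on compound 2

The source may report more compounds than this note shows. Statements on the series, on what has been measured and on what is new or still open speak of the compounds shown alone.

In a functional assay on MV4-11 cells (Homo sapiens) for antiproliferative activity, read by luminescence and CellTiter-Glo, with a stated time of 72 h (a higher number here means a weaker inhibitor, a lower number a stronger inhibitor), compound 1 (`COc1cc(F)ccc1Nc1nn(C2CCCCO2)c2ccc(-c3c(C)noc3C)cc12`) gives 17500 nM and compound 2 (`CNc1cc(-c2ccc3cnn(Cc4ccc(OC)cc4)c3c2)cn(C)c1=O`) gives 2700 nM as the lower of the two numbers, a gap beyond the usual scatter. Compound 3 (`CNc1cc(-c2ccc3cnn(Cc4ccc(C(F)(F)F)cc4)c3c2)cn(C)c1=O`) differs from compound 2 by trifluoromethyl in place of methoxy on an aromatic carbon, para to a large group (trifluoromethyl in place of methoxy on an aromatic carbon). Going by the values given here, no measured pair shows this change, and only a modest shift can be expected. The estimated step is a 1.3-fold higher number from compound 2 to compound 3 (0.11 log units; within the scatter) in this assay and stays within the scatter, leaning slightly toward weaker inhibition. Compound 3 is expected at 3500 nM within a range of 1000 nM to 10000 nM in this measurement.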

Compound 3, half-maximal inhibitory concentration: 4370 nM
Beside the measured number, compound 3's estimate is 1.2-fold (0.10 log units) below it; the measured number falls inside the stated range.
By their numbers in this assay, from the lowest: compounds 2 and 3 (each within the scatter of the next); then compound 1.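

In this assay, the change from 4-methoxyphenyl to 4-(trifluoromethyl)phenyl gives a 1.6-fold higher number from compound 2 to compound 3 (0.21 log units; within the scatter), so compound 2 and compound 3 cannot be told apart. At this position, then, methoxy, which counts one hydrogen-bond acceptor, and trifluoromethyl, which counts none, give numbers within the scatter of each other. Nothing measured here offers an explanation for this result. Still open, on these data alone, is whether a different group at this position, such as an amine or a carboxylic acid, would give a step beyond the scatter. These two groups alone cannot show how far this position tolerates change.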